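Anilino for piperidinyl on the propyl chain

The source may report more compounds than this note shows. Statements on the series, on what has been measured and on what is new or still open speak of the compounds shown alone.

Measured compounds, in a functional assay on HL-60 cells (Homo sapiens) for antiproliferative activity, read by MTT assay, with a stated time of 48 h; on this read-out higher numbers stand for weaker inhibition and lower numbers for stronger inhibition:
compound 1 `CCN(CC)CCCn1c(N)c(-c2nc3ccccc3[nH]2)c2nc(C#N)c(C#N)nc21` gives > 730 nM, a limit of the assay;
compound 2 `N#Cc1nc2c(-c3nc4ccccc4[nH]3)c(N)n(CCCO)c2nc1C#N` gives > 50000 nM, also a limit of the assay;
compound 3 `N#Cc1nc2c(-c3nc4ccccc4[nH]3)c(N)n(CCCN3CCCCC3)c2nc1C#N` gives 1680 nM.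

Compound 3 holds the only number shown; the other two values are limits. The unmeasured compound 4 `N#Cc1nc2c(-c3nc4ccccc4[nH]3)c(N)n(CCCNc3ccccc3)c2nc1C#N` differs from compound 3 by one change: anilino in place of piperidin-1-yl on a saturated chain carbon, three bonds along the chain from an aromatic nitrogen. Of the measured steps, only an at least 29-fold lower number from compound 2 to compound 3 (1.47 log units; beyond the scatter) is readable, and it bears only loosely on this change, since a hydroxy group, not an anilino group, is the comparator there. The step that the limit leaves unreadable from compound 1 to compound 3 cannot be sized. The anilino group shares nothing with the two substituents already compared except its place on the chain, so the expectation is weak; a moderately higher number than compound 3 is estimated, a 3.0-fold higher number from compound 3 to compound 4 (0.47 log units; beyond the scatter), giving for compound 4 an estimated 5000 nM with a range from 1000 nM to 30000 nM.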

Compound 4, half-maximal inhibitory concentration: 6920 nM
Compound 4: the middle estimate sits 1.4-fold (0.14 log units) below what was measured; measured number inside the range.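

In this assay, anilino in place of piperidin-1-yl on the propyl chain brings a 4.1-fold higher number from compound 3 to compound 4 (0.61 log units; beyond the scatter), so the two ring-bearing amino groups are not interchangeable at this place. Anilino in place of hydroxy brings an at least 7.2-fold lower number from compound 2 to compound 4 (0.85 log units; beyond the scatter), which shows that the anilino compound still keeps a measurable value, although the value of compound 2 is a limit. The step from compound 1 to compound 4 cannot be read, because the value of compound 1 is a limit: the limit of > 730 nM in this assay, at which 1 of the 4 values shown sits.

The compounds shown leave open whether the aromatic ring or the amine hydrogen of anilino goes with this step. Going by these compounds, how a benzylamino group, a morpholin-4-yl group or a longer chain would read here also stays open.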